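The source may report more compounds than this note shows. Statements on the series, on what has been measured and on what is new or still open speak of the compounds shown alone.

Of the compounds shown here, three that share one core have been measured in a functional assay on A549 cells (Homo sapiens) for antiproliferative activity, read by MTT assay, with a stated time of 48 h; a higher number here means a weaker inhibitor, a lower number a stronger inhibitor. Compound 1 (`COc1ccc(C(=O)/C=C/c2cc(Cl)cc(Cl)c2Oc2c([N+](=O)[O-])cc(C(F)(F)F)cc2[N+](=O)[O-])cc1`) gives 12.6 ug/mL, compound 2 (`O=C(/C=C/c1cc(Cl)cc(Cl)c1Oc1c([N+](=O)[O-])cc(C(F)(F)F)cc1[N+](=O)[O-])c1ccc(F)cc1`) gives 29.4 ug/mL, and compound 3 (`O=C(/C=C/c1cccc(Cl)c1Oc1c([N+](=O)[O-])cc(C(F)(F)F)cc1[N+](=O)[O-])c1ccc(F)cc1`) gives 23.8 ug/mL. Compound 2 therefore has a clearly higher number than compound 1 but cannot be separated from compound 3, as the data show a 1.2-fold lower number from compound 2 to compound 3 (0.09 log units; within the scatter).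

The next comparison is with compound 4 (`O=C(/C=C/c1cc(Cl)cc(Cl)c1Oc1c([N+](=O)[O-])cc(C(F)(F)F)cc1[N+](=O)[O-])c1ccc(Br)cc1`), which has bromo in place of fluoro on an aromatic carbon, para to a large group: bromo in place of fluoro on an aromatic carbon. Among the compounds with values here, only one measured step involves this same position, and it is modest: a 2.3-fold higher number from compound 1 to compound 2 (0.37 log units; beyond the scatter). The other step, with hydrogen in place of chloro on an aromatic carbon, lies elsewhere in the molecule and stays within the scatter, so it offers little guidance. Within the data shown here, no bromo compound has yet been measured in this set, and the direction of the change cannot be read from the data with any confidence. In this assay, a shift no larger than the one seen at this position is expected, most likely none beyond the scatter. The expected change is a 1.3-fold lower number from compound 2 to compound 4 (0.11 log units; within the scatter). For compound 4 the estimated value is 23 ug/mL, within an expected range of 11 ug/mL to 45 ug/mL.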

Compound 4, half-maximal inhibitory concentration: 14.5 ug/mL
Compound 4: the middle estimate sits 1.6-fold (0.20 log units) above what was measured; the range from low to high includes it.
By their numbers in this assay, from the lowest: compounds 1, 4, 3 and 2 (each within the scatter of the next, the first and the last beyond it).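

In this assay the change from 4-fluorophenyl to 4-bromophenyl gives a 2.0-fold lower number from compound 2 to compound 4 (0.31 log units; beyond the scatter) and so shows that this position, on an aromatic carbon para to a large group, responds to an exchange of one halogen for another, and not only to the exchange of methoxy for fluoro seen earlier. Within the data shown here, with a 1.2-fold higher number from compound 1 to compound 4 (0.06 log units; within the scatter) as the other new step, bromo and methoxy cannot be told apart at this position, while fluoro is the one of the three groups whose steps to both others lie beyond the scatter. Nothing available here accounts for this difference between the groups.

The compounds shown leave open whether fluoro is the exception at this position or whether other groups, such as an amine, a carboxylic acid or a longer alkoxy chain, would also fall level with bromo and methoxy. They also leave open whether the same exchange would give a similar step on the core of compound 3, which carries one chloro fewer, since bromo appears here only on the core that carries both.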